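Pyridine Arm in Place of an Ether Tail

A few compounds are considered here, and "the series" means these few. Any claim that something is new, unique, unknown or untested is made for them only; others in the source may bear on it.

Measured compounds:
Compound 1 `CCc1nc(N(C)C)nc(N[C@@H]2C[C@H](CO)[C@@H](O)[C@H]2O)c1-c1nc2ccccc2s1` – in an ADME assay on cells (Homo sapiens) for cytotoxicity, read by polymerase chain reaction, with a stated time of 3 days (on this read-out higher numbers stand for lower toxicity in this test and lower numbers for higher toxicity in this test), compound 1 gives > 25000 nM, which is a limit of the assay and not a number.
Compound 2 `COCCNc1nc(C)c(-c2nc3ccccc3s2)c(N[C@@H]2C[C@H](CO)[C@@H](O)[C@H]2O)n1` – in this assay compound 2 gives 21000 nM.

Both measured compounds share the same core and the same sugar-like ring bearing three hydroxyl groups, and both sit at the weak end of this test. Within the data shown here, compound 2 is the only compound with an actual number in this assay; the other value is a limit (the limit of > 25000 nM in this assay, at which 1 of the 2 values shown sits). Among the measured compounds shown here, the two measured compounds differ in more than one place, so no single step between them can be read, and only what each shows on its own can be stated.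

Compound 3 `Cc1nc(NCc2ccncc2)nc(N[C@@H]2C[C@H](CO)[C@@H](O)[C@H]2O)c1-c1nc2ccccc2s1` differs from compound 2 in one place: pyridin-4-yl in place of methoxymethyl on a saturated chain carbon bound to a nitrogen on an aromatic ring. For the measured compounds named here, no measured step speaks to this kind of change, so the step from compound 2 to compound 3 in this assay is expected to be a 1.1-fold lower number from compound 2 to compound 3 (0.02 log units; within the scatter), a shift no larger than the usual scatter. Compound 3 is therefore estimated at 20000 nM, with a range from 8000 nM to 50000 nM.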

Compound 3, half-maximal cytotoxic concentration: 7000 nM
Estimate against measurement, compound 3: 2.9-fold (0.46 log units) above; the whole stated range lies above it.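

In this assay, pyridin-4-yl in place of methoxymethyl on a saturated chain carbon bound to a nitrogen on an aromatic ring brings a 3.0-fold lower number from compound 2 to compound 3 (0.48 log units; beyond the scatter), and a lower number here stands for higher toxicity in this test. Among these compounds, this is the only step that can be read so far, and it shows that the group carried on this chain can move the result beyond the usual scatter while the rest of the molecule stays the same. Compound 1 differs from compound 3 in more than one place and its value is a limit and not a number, so it adds nothing to this step: the limit of > 25000 nM in this assay, at which 1 of the 3 values shown sits.

The compounds shown leave open whether the step goes with the aromatic ring as such or with the nitrogen inside it, and a benzyl group in place of (pyridin-4-yl)methyl would speak to that. They also leave open how the result depends on the length of the chain, as a 2-(pyridin-4-yl)ethyl group would test, and no measured property accounts for the step.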